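The source may hold more compounds than are shown below. What is called first, only, known or untested is meant among the compounds shown, and "the series" means these compounds.

Measured so far in an ADME assay on MT4 cells (Homo sapiens) for cytotoxicity, read by MTT assay, with a stated time of 96 h; on this read-out lower numbers stand for higher toxicity in this test and higher numbers for lower toxicity in this test:
Compound 1 `COc1ccc(-c2nc3cc(C(F)(F)F)ccc3[nH]2)cc1` gives 2000 nM.
Compound 2 `O=[N+]([O-])c1ccc(-c2nc3ccccc3[nH]2)c([N+](=O)[O-])c1` gives 7000 nM.
Compound 3 `O=[N+]([O-])c1ccccc1-c1nc2ccccc2[nH]1` gives 60000 nM.

Compound 3 and compound 2 differ in one place, (nitro in place of hydrogen on an aromatic carbon), and that change produced an 8.6-fold lower number from compound 3 to compound 2 (0.93 log units; beyond the scatter). Compound 4 `COc1ccc(-c2nc3cc(C(F)(F)F)ccc3[nH]2)c([N+](=O)[O-])c1` is not yet measured. It arises from compound 1 by the same kind of change, (nitro in place of hydrogen on an aromatic carbon), but the surroundings of the place differ: in compound 2 the entering group sits meta to a nitro group and para to a group of 9 heavy atoms, whereas in compound 4 it sits ortho to a large group and meta to a methoxy group. The difference between the cores of compound 1 and compound 3 is not broken down here. For the measured compounds named here, compound 4 is expected to show a 2.9-fold lower number from compound 1 to compound 4 (0.46 log units; beyond the scatter) in this assay, a smaller step than the earlier one, since the only guide is an 8.6-fold lower number from compound 3 to compound 2 (0.93 log units; beyond the scatter) on a different core with different neighbours. The estimate for compound 4 is 700 nM, expected to fall between 200 nM and 3000 nM.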

Compound 4, half-maximal cytotoxic concentration: 85000 nM
Beside the measured number, compound 4's estimate is 120-fold (2.08 log units) below it; measured number above the stated range.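

In this assay, putting nitro in place of a hydrogen on an aromatic carbon gave a 43-fold higher number from compound 1 to compound 4 (1.63 log units; beyond the scatter) on the core of compound 1, so the number moved the opposite way from the earlier step on the other core. The two results disagree by more than repeat measurements would explain: the same change on two cores in this assay, an 8.6-fold lower number (0.93 log units; beyond the scatter) from compound 3 to compound 2 and a 43-fold higher number (1.63 log units; beyond the scatter) from compound 1 to compound 4, 360-fold (2.56 log units) apart, beyond the scatter of two such steps. For the compounds shown here, this shows that the size and direction of the step did not carry over between these two cores, but with only two pairs it does not show which difference between the cores or the surroundings of the place matters.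

The compounds shown leave open whether an amine or a carboxylic acid in place of that hydrogen on the core of compound 1 would also raise the number. They also leave open whether nitro at another place on that ring would behave as it does in compound 4.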